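A Phosphate Carrier and a Swap of Fluoro for Hydroxy

The compounds below may be only part of what the source reports. "The series", "measured", "known", "first", "only" and "open" are said of these compounds alone.

Compound 1 `Cc1cn([C@H]2C[C@H](CF)[C@@H](CO)O2)c(=O)[nH]c1=O`: 970000 nM
Compound 2 `Cc1cn([C@H]2C[C@H](CF)[C@@H](COP(=O)(O)O)O2)c(=O)[nH]c1=O`: 40000 nM
Compound 3 `Cc1cn([C@@H]2O[C@H](CO)[C@@H](CN)[C@H]2O)c(=O)[nH]c1=O`: 110000 nM

In an assay on isolated protein for inhibition of thymidine kinase, cytosolic (Homo sapiens) (a lower number here means a stronger inhibitor, a higher number a weaker inhibitor), compound 2 gives the lowest of the three numbers; compound 3 sits higher, and compound 1 higher still. For the measured compounds named here, the only step measured so far, a 24-fold lower number from compound 1 to compound 2 (1.38 log units; beyond the scatter), replaced a hydrogen on an oxygen with a much larger group. Compound 4 `Cc1cn([C@H]2C[C@H](CO)[C@@H](COP(=O)(O)O)O2)c(=O)[nH]c1=O` differs from compound 2 in another place: hydroxy in place of fluoro on a saturated chain carbon bound to a saturated ring carbon. Going by the values given here, no measured pair shows this exchange, and the step already measured offers no guide to it. With nothing to lean on, the expected change is one within the usual scatter, no change at the digits printed from compound 2 to compound 4 (within the scatter). Compound 4 is therefore estimated at 40000 nM, with a range from 13000 nM to 120000 nM.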

Compound 4, inhibition constant: 43500 nM
For compound 4 the middle estimate is 1.1-fold (0.04 log units) below the measured one, and the stated range covers the measured number.
By their numbers in this assay, from the lowest: compounds 2 and 4 (each within the scatter of the next); then compound 3; then compound 1.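

In this assay the exchange of fluoro for hydroxy gives a 1.1-fold higher number from compound 2 to compound 4 (0.04 log units; within the scatter), so at this position, with the phosphate in place, the measured number does not separate the two groups. The hydroxy brings a hydrogen-bond donor and acceptor that the fluoro lacks, yet no difference beyond the scatter appears. Nothing available explains why the two groups read alike. On these data alone, whether an amine or a longer chain on this carbon would also read alike remains open. So does whether the same exchange would leave compound 1, which has no phosphate, equally unchanged.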